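Acetyl to methyl on the aryl oxygen of compound 1

The source may hold more compounds than are shown below. What is called first, only, known or untested is meant among the compounds shown, and "the series" means these compounds.

Going by the values given here, compound 1 `COc1ccc(/C=C2\CCCN=C2c2cccnc2)c(OC(C)=O)c1` gives 770 nM in an assay on membranes from brain for displacement of a labelled ligand from Neuronal acetylcholine receptor; alpha4/beta2 (Rattus norvegicus), with a stated time of 3 h (a higher number here means a weaker inhibitor, a lower number a stronger inhibitor), the second highest of the three numbers measured so far. Compound 3 `CC(=O)Oc1ccccc1/C=C1\CCCN=C1c1cccnc1` gives 700 nM in this assay, and compound 2 `CC(C)(C)Oc1ccc(/C=C2\CCCN=C2c2cccnc2)cc1` gives 2170 nM. Among the compounds with values here, the one single-point step measured, a 1.1-fold lower number from compound 1 to compound 3 (0.04 log units; within the scatter), lies within the scatter and concerns a different place on the core than the change now followed. Compound 4 `COc1ccc(/C=C2\CCCN=C2c2cccnc2)c(OC)c1` differs from compound 1 by methyl in place of acetyl on an oxygen on an aromatic ring. Within the data shown here, no measured step alters the group on this oxygen, so the measured steps give no direct guide; the values of compound 2 and compound 1 show only that a compound with another alkoxy pattern sat at a higher number, without a single-point comparison to draw on. The expectation is therefore a step of no settled direction, most likely within the scatter, with a 1.3-fold lower number from compound 1 to compound 4 (0.11 log units; within the scatter) as the central estimate. Compound 4 is expected at 600 nM, within a range from 250 nM to 1500 nM.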

Compound 4, inhibition constant: 250 nM
For compound 4 the middle estimate is 2.4-fold (0.38 log units) above the measured one; low and high end bracket the measured number.
By their numbers in this assay, from the lowest: compound 4; then compounds 3 and 1 (each within the scatter of the next); then compound 2.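

In this assay the group on this oxygen makes a measurable difference: acetoxy to methoxy gives a 3.1-fold lower number from compound 1 to compound 4 (0.49 log units; beyond the scatter) and is the only listed step beyond the scatter. The earlier step of a 1.1-fold lower number from compound 1 to compound 3 (0.04 log units; within the scatter) lay within the scatter and concerned another place on the shared core, so this position is the one of the two that shows a response so far. This reading rests on a single pair, and no accompanying measurement speaks to the reason for the step.

Going by these compounds, it remains open whether a free hydroxyl, an ethoxy group or a longer alkoxy chain on this oxygen would extend the step or reverse it. On these data alone, it is also open whether acetyl to methyl gives a step of similar size on compound 3, which carries hydrogen in place of the other methoxy group.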